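The source may hold more compounds than are shown below. What is called first, only, known or untested is meant among the compounds shown, and "the series" means these compounds.

Measured values (a functional assay on MCF7 cells (Homo sapiens) for antiproliferative activity, read by MTT assay, with a stated time of 24 h; on this read-out higher numbers stand for weaker inhibition and lower numbers for stronger inhibition)
- compound 1 `CCn1c(C(=O)N[C@@H](C)CO)ccc1C(CC)(CC)c1ccc(OCS(=O)(=O)c2ccccc2)c(C)c1` gives 10800 nM
- compound 2 `CCn1c(C(=O)N[C@@H](CO)C(C)C)ccc1C(CC)(CC)c1ccc(OCS(=O)(=O)c2ccccc2)c(C)c1` gives 18800 nM
- compound 3 `CCn1c(C(=O)NCC(=O)O)ccc1C(CC)(CC)c1ccc(OCS(=O)(=O)c2ccccc2)c(C)c1` gives 33100 nM

Compound 3 stands at the upper end of these numbers. Its gap to one neighbour is beyond the scatter (a 3.1-fold higher number from compound 1 to compound 3 (0.49 log units; beyond the scatter)), while its gap to the other is within it (a 1.8-fold higher number from compound 2 to compound 3 (0.25 log units; within the scatter)).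

Compound 4 `CCn1c(C(=O)N[C@@H](CCC(=O)O)C(=O)O)ccc1C(CC)(CC)c1ccc(OCS(=O)(=O)c2ccccc2)c(C)c1` carries 2-carboxyethyl in place of hydrogen on a saturated chain carbon bound to an amide-type nitrogen and a carbonyl carbon. For the measured compounds named here, no measured step adds this group. The nearest evidence is the set of changes on the same amide-type nitrogen, which stay small (a 1.7-fold higher number from compound 1 to compound 2 (0.24 log units; within the scatter)) or modest (a 3.1-fold higher number from compound 1 to compound 3 (0.49 log units; beyond the scatter)). On that evidence, no change beyond the scatter is expected in this assay, with any drift more likely toward a higher number (a 1.2-fold higher number from compound 3 to compound 4 (0.08 log units; within the scatter)). The estimate for compound 4 is 40000 nM, with an expected range of 15000 nM to 95000 nM.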

Compound 4, half-maximal inhibitory concentration: > 50000 nM
Compound 4: a limit, no number (the forecaster's own chance of this, stated with the estimate: 25%); at least 1.2-fold (0.09 log units) between middle value and limit.
By their numbers in this assay, from the lowest: compounds 1, 2 and 3 (each within the scatter of the next, the first and the last beyond it). At a limit, above all of these: compound 4.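

In this assay compound 4 gives a limit, not a number: the limit of > 50000 nM in this assay, at which 1 of the 4 values shown sits. Placing 2-carboxyethyl on the saturated chain carbon bound to an amide-type nitrogen and a carbonyl carbon gives an at least 1.5-fold higher number from compound 3 to compound 4 (0.17 log units; that floor lies within the scatter), so the size of this step remains unsettled. On the amide-type nitrogen, 1,3-dicarboxypropyl gives an at least 2.6-fold higher number from compound 2 to compound 4 (0.42 log units; beyond the scatter), which carboxymethyl did not do against the same group, and it also gives an at least 4.6-fold higher number from compound 1 to compound 4 (0.66 log units; beyond the scatter).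

The compounds shown leave open whether the shift follows the second carboxylic acid or the longer chain alone. A methyl ester or an amine at the end of the same chain would bear on that question in this assay.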